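Cytotoxicity series: trifluoromethyl to fluoro on the aryl ring

The compounds below may be only part of what the source reports. "The series", "measured", "known", "first", "only" and "open" are said of these compounds alone.

Compound 1 `CN1C/C(=C\c2ccncc2)C(=O)/C(=C/c2ccccc2F)C1` and compound 2 `CN1C/C(=C\c2ccncc2)C(=O)/C(=C/c2ccccc2C(F)(F)F)C1` share one core; compound 3 `O=C1/C(=C/c2cccnc2)CN(S(=O)(=O)c2ccc(C(F)(F)F)cc2)C/C1=C\c1ccccc1F` and compound 4 `O=C1/C(=C/c2cccnc2)CN(S(=O)(=O)c2ccc(F)cc2)C/C1=C\c1ccccc1F` share another. The difference between the two cores is not broken down here. In a functional assay on HepG2 cells (Homo sapiens) for cytotoxicity, read by MTT assay, with a stated time of 24 h (a lower number here means a stronger inhibitor, a higher number a weaker inhibitor), compound 1 gives 4600 nM, compound 2 gives 3300 nM and compound 3 gives 2400 nM. Among the compounds with values here, the one measured single-point change, (fluoro in place of trifluoromethyl on an aromatic carbon), reads a 1.4-fold higher number from compound 2 to compound 1 (0.14 log units; within the scatter). The change into compound 4, (fluoro in place of trifluoromethyl on an aromatic carbon), is the same kind of change, not the same: the place is para to a large group where the earlier one was ortho to a large group. The step expected from compound 3 to compound 4 in this assay is a 1.3-fold higher number from compound 3 to compound 4 (0.12 log units; within the scatter), resting on a 1.4-fold higher number from compound 2 to compound 1 (0.14 log units; within the scatter) alone. Compound 4 is therefore estimated at 3200 nM, with a range of 1500 nM to 7000 nM.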

Compound 4, half-maximal inhibitory concentration: 15600 nM
For compound 4 the middle estimate is 4.9-fold (0.69 log units) below the measured one, and the stated range ends below it.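

In this assay the change from 4-(trifluoromethyl)phenyl to 4-fluorophenyl reads a 6.5-fold higher number from compound 3 to compound 4 (0.81 log units; beyond the scatter). Within the data shown here, the same change does not carry a single step size from one core to the other: the same change on two cores in this assay, a 1.4-fold higher number (0.14 log units; within the scatter) from compound 2 to compound 1 and a 6.5-fold higher number (0.81 log units; beyond the scatter) from compound 3 to compound 4, 4.7-fold (0.67 log units) apart, beyond the scatter of two such steps With only one pair on each core, and the change in a different place in each pair, the data do not show whether the core or the place accounts for the gap, and they give no rule for a third core.

The compounds shown leave open how other groups at this place, such as chloro, methoxy or an amine, would read on either core. Also open, from the compounds shown here alone, is how trifluoromethyl and fluoro compare when they sit in the same place on both cores.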